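Inverting Every Stereocentre of Compound 2

The source may hold more compounds than are shown below. What is called first, only, known or untested is meant among the compounds shown, and "the series" means these compounds.

Compound 1 `Cc1ccc([C@H]2NC[C@@H](O)[C@@H]2O)cc1`: 0%
Compound 2 `O[C@H]1[C@H](O)CN[C@@H]1CCCc1ccccc1`: 20.6%

In an assay on isolated protein for inhibition of alpha-mannosidase (Canavalia ensiformis), read by spectrophotometry, tested at 1000 uM (a lower number here means less inhibition, a higher number more inhibition at the concentration tested (going by the name of the read-out)), compound 1 gives 0%, while compound 2 gives 20.6%. Of the two numbers, compound 2 stands highest; its nearest neighbour, compound 1, lies lower by a gap that is beyond the usual scatter.

Compound 3 `O[C@H]1[C@H](CCCc2ccccc2)NC[C@@H]1O` is the mirror image of compound 2: the two compounds have the same atoms and bonds and differ only in configuration as drawn: 3 of 3 stereo elements differ (all stereocentres are inverted: mirror images); a stereocentre at a saturated ring carbon is drawn R in compound 2 and S in compound 3; a stereocentre at a saturated ring carbon is drawn R in compound 2 and S in compound 3; a stereocentre at a saturated ring carbon is drawn R in compound 2 and S in compound 3. Among the compounds with values here, no pair of measured compounds differing in a single place is available, so the size of such a step has no precedent here, and the two measured compounds give no hint of its direction. The step from compound 2 to compound 3 is estimated at a number 10.6 percentage points lower from compound 2 to compound 3 (beyond the scatter), a moderate fall, though a change within the scatter, or a rise, cannot be ruled out. Compound 3 is expected to give 10%, in a range from 0% to 35%.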

Compound 3, a percentage reported as inhibition, at one concentration (the size of the read-out at that concentration, not a potency): 11.5%
Compound 3: the middle estimate sits 1.5 percentage points below what was measured; low and high end bracket the measured number.
By their numbers in this assay, from the lowest: compound 1; then compounds 3 and 2 (each within the scatter of the next).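

Within the data shown here, the mirror-image pair gives the first step that can be tied to one kind of change, and in this assay inverting all three stereocentres amounts to a number 9.1 percentage points lower from compound 2 to compound 3 (within the scatter). At this single concentration, the read-out therefore does not separate the two mirror forms, and no preference for either hand can be claimed. The comparison isolates configuration from every other structural feature because nothing else changes between the pair: the fact that compounds 2 and 3 differ only in the configuration as drawn

From the compounds shown here alone, what inverting only one or two of the stereocentres would do remains open, since complete inversion says nothing about each centre alone. Going by these compounds, it is equally open whether a longer chain, or an amine in place of the present side chain, would make the two mirror forms differ in this assay.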